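This account rests on a few compounds, and the source may have more. Where it says the series, first, only, none or still open, it means among the compounds named here.

Measured compounds in a functional assay for inhibition, with Rattus norvegicus as the target, using microsomes; on this read-out higher numbers stand for weaker inhibition and lower numbers for stronger inhibition:
- compound 1 `COc1ccc2c(=O)cc(-c3ccc(O)c(O)c3)oc2c1`: 2500 nM
- compound 2 `O=C(O)COc1c(-c2ccc(O)c(O)c2)oc2ccccc2c1=O`: 6500 nM
- compound 3 `CN(C)CCCOc1c(-c2ccc(O)c(O)c2)oc2ccccc2c1=O`: 1000 nM

Compound 3 gives the lowest number of the three in this assay; compound 1 sits nearest to it and compound 2 furthest from it, both gaps lying beyond the scatter. Among the compounds with values here, the one single-point step measured so far, a 6.5-fold lower number from compound 2 to compound 3 (0.81 log units; beyond the scatter), comes from replacing carboxy with 2-(dimethylamino)ethyl on a saturated chain carbon bound to an oxygen on an aromatic ring.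

Compound 4 `C[N+](C)(C)CCCCCCCCOc1c(-c2ccc(O)c(O)c2)oc2ccccc2c1=O` differs from compound 3 as follows: a group of 9 heavy atoms (8 carbon, 1 nitrogen; no ring) in place of a group of 3 heavy atoms (2 carbon, 1 nitrogen; no ring), on a saturated chain carbon, three bonds along the chain from an oxygen on an aromatic ring. Within the data shown here, no measured step covers a change of this kind; the step from compound 2 to compound 3 concerns the same chain region but a different pair of groups, so it bears on the present case only loosely. Since a nitrogen-bearing chain at this position already gives the lowest number in compound 3, and the new group keeps a nitrogen in the chain, the expectation for compound 4 is a step of about a 1.1-fold lower number from compound 3 to compound 4 (0.05 log units; within the scatter), not clearly beyond the scatter in either direction. The estimate for compound 4 in this assay is therefore 900 nM, with a range from 250 nM to 3500 nM.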

Compound 4, half-maximal inhibitory concentration: 1000 nM
The estimate for compound 4 lay 1.1-fold (0.05 log units) below the measured number; the measured number falls inside the stated range.
By their numbers in this assay, from the lowest: compounds 3 and 4 (each within the scatter of the next); then compound 1; then compound 2.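

In this assay, the place on a saturated chain carbon, three bonds along the chain from an oxygen on an aromatic ring, accepts a much larger group than dimethylamino: the group of 9 heavy atoms with net charge +1 gives no change at the digits printed from compound 3 to compound 4 (within the scatter). Neither the larger group nor the net charge, arriving together in this single step, moves the number beyond the scatter, and this one step cannot separate the two differences. No measurement at hand explains this flat result.

As far as these compounds go, whether a plain alkyl chain with no nitrogen, or a primary amine on a chain of the same length, would give a similar number at this place remains open. Also open, from the compounds shown here alone, is whether a carboxylic acid at the end of a longer chain would follow compound 4 or differ from it.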